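A few compounds are considered here, and "the series" means these few. Any claim that something is new, unique, unknown or untested is made for them only; others in the source may bear on it.

Compound 1 `O=C1NC(O)(CCn2cnc3ccnc(Cl)c32)C(OCc2ccccc2)=C1OCc1ccccc1` and compound 4 `O=C1NC(O)(CCn2cnc3cc[nH]c3c2=O)C(OCc2ccccc2)=C1OCc1ccccc1` share the same core; they differ in the group attached to the chain that hangs from it. In a functional assay on CCRF-CEM cells (Homo sapiens) for antiproliferative activity, read by MTT assay, with a stated time of 72 h (a lower number here means a stronger inhibitor, a higher number a weaker inhibitor), compound 1 gives "not determined" (no result reported), that is, no result was reported for it, so it stands without a number. The same holds for compound 2 `O=C1O/C(=C\Cn2cnc3c(Cl)c(F)nc(F)c32)C(OCc2ccccc2)=C1OCc1ccccc1`: in this assay compound 2 gives "not determined" (no result reported), and no result was reported for it either. Only compound 3 `O=C1O/C(=C\Cn2cnc3cc[nH]c3c2=O)C(OCc2ccccc2)=C1OCc1ccccc1` gives a number: in this assay compound 3 gives 16000 nM.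

The change from compound 1 to compound 4 is a group of 10 heavy atoms (6 carbon, 3 nitrogen, 1 oxygen; one five-membered aromatic ring with 1 hetero atom, one six-membered aromatic ring with 2 hetero atoms) in place of a group of 10 heavy atoms (6 carbon, 3 nitrogen, 1 chlorine; one five-membered aromatic ring with 2 hetero atoms, one six-membered aromatic ring with 1 hetero atom), on a saturated chain carbon, two bonds along the chain from a saturated ring carbon. Compound 1 has no number. Among the compounds with values here, no step can be drawn from it, and no direction or size of step follows from the two structures alone. Compound 3 carries the same entering group as compound 4, on a different core, and is the only anchor available.

Resting on compound 3 with its value of 16000 nM, compound 4 is expected to give about 20000 nM in this assay, within a wide range from 5000 nM to 80000 nM.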

Compound 4, half-maximal inhibitory concentration: 87000 nM
Compound 4: the middle estimate sits 4.4-fold (0.64 log units) below what was measured; measured number above the stated range.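

In this assay, within the data shown here, compound 1 has no single number, so no step from it to compound 4 can be read. The compounds shown leave open how exchanging the group on the chain changes activity on the shared core. No further data bear on this result.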